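The compounds below may be only part of what the source reports. "The series", "measured", "known", "first", "only" and "open" are said of these compounds alone.

Measured compounds:
compound 1, `O=C1/C(=C/c2ccccc2)CCC/C1=C\c1cccc(O)c1`, 28400 nM;
compound 3, `O=C1/C(=C/c2ccccc2)CCC/C1=C\c1ccc(O)c(O)c1`, 20300 nM;
compound 2, `O=C(/C=C(O)/C=C/c1ccc(O)cc1)c1ccccc1O`, "not determined" (no result reported).

In an assay on isolated protein for inhibition of Alpha glucosidase (Homo sapiens), with stated times of 5 min and 15 min (on this read-out lower numbers stand for stronger inhibition and higher numbers for weaker inhibition), compound 1 gives 28400 nM and compound 3 gives 20300 nM; the step of a 1.4-fold lower number from compound 1 to compound 3 (0.15 log units; within the scatter) comes from the change (hydroxy in place of hydrogen on an aromatic carbon). Compound 4, `O=C(/C=C(O)/C=C/c1ccc(O)c(O)c1)c1ccccc1O`, arises from compound 2 by the change (hydroxy in place of hydrogen on an aromatic carbon), the same kind of change, though here the entering hydroxy sits meta to a large group rather than para to it. The difference between the two cores is not broken down here. From the compounds shown here alone, for compound 2 no number exists in this assay, so the step from compound 2 to compound 4 is expected to be small in this assay, as the earlier one was, but its starting point is unknown. Compound 4 is therefore expected to give about 15000 nM, estimated between 3000 nM and 70000 nM.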

Compound 4, half-maximal inhibitory concentration: 14300 nM
The estimate for compound 4 lay 1.0-fold (0.02 log units) above the measured number; the range from low to high includes it.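

In this assay, among the compounds shown here, compound 4 gives 14300 nM, but compound 2 has no number there, so no step from compound 2 to compound 4 can be read. The compounds shown leave open what the entering hydroxy does on the core of compound 2. No evidence given here bears on this result.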